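Nitro in Place of Fluoro on the Aryl Ring

The source may hold more compounds than are shown below. What is called first, only, known or untested is meant among the compounds shown, and "the series" means these compounds.

Of the compounds shown here, two sharing one core have been measured in a functional assay on LNCaP cells (Homo sapiens) for cytotoxicity, read by MTT assay, with a stated time of 72 h; a higher number here means a weaker inhibitor, a lower number a stronger inhibitor. Compound 1 `CC1=C(/C=C/C(=O)/C=C/c2cccc(C(F)(F)F)c2)C(C)(C)CCC1` gives 2800 nM, while compound 2 `CC1=C(/C=C/C(=O)/C=C/c2cccc(F)c2)C(C)(C)CCC1` gives 12900 nM, the highest of the two numbers. For the measured compounds named here, the only measured step, a 4.6-fold higher number from compound 1 to compound 2 (0.66 log units; beyond the scatter), shows that putting fluoro where trifluoromethyl stood raised the number beyond the scatter. Compound 3 `CC1=C(/C=C/C(=O)/C=C/c2cccc([N+](=O)[O-])c2)C(C)(C)CCC1` has not yet been measured; it differs from compound 2 by nitro in place of fluoro on an aromatic carbon. Going by the values given here, the one step that bears on this change is a 4.6-fold higher number from compound 1 to compound 2 (0.66 log units; beyond the scatter), in which a single fluorine took the place of a bulkier substituent at the same position and the number rose modestly. With compound 3 again entering a group of three heavy atoms in place of the single fluorine, a modest fall in this assay is expected, as a 2.6-fold lower number from compound 2 to compound 3 (0.41 log units; beyond the scatter). Compound 3 is therefore estimated at 5000 nM, with a range from 1500 nM to 16000 nM.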

Compound 3, half-maximal inhibitory concentration: 2700 nM
For compound 3 the middle estimate is 1.9-fold (0.27 log units) above the measured one; measured number inside the range.
By their numbers in this assay, from the lowest: compounds 3 and 1 (each within the scatter of the next); then compound 2.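

At this position, nitro in place of fluoro gives a 4.8-fold lower number from compound 2 to compound 3 (0.68 log units; beyond the scatter) and so shows that a second group, besides trifluoromethyl, stands clear of fluoro beyond the scatter. Nitro in place of trifluoromethyl gives a 1.0-fold lower number from compound 1 to compound 3 (0.02 log units; within the scatter) and the two groups cannot be told apart here, which leaves fluoro as the one group of the three with the higher number. Nothing measured here accounts for this order among the three groups.

From the compounds shown here alone, three groups on one aromatic carbon cannot show whether the level shared by nitro and trifluoromethyl is the lowest this position allows, and what an amine, a carboxylic acid or a methoxy group would give in its place stays open. Going by these compounds, whether the same order would hold with these groups on a different core also remains unknown.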